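The source may report more compounds than this note shows. Statements on the series, on what has been measured and on what is new or still open speak of the compounds shown alone.

The series shares one core: a sulfonamide-linked piperidine bearing a 4-methylpiperidine, carried by different aromatic rings. Compound 1 `Cc1cc(C)c(S(=O)(=O)N2CCC(N3CCC(C)CC3)CC2)c(C)c1` gives 0.03 nM in a functional assay on DLD-1 cells (Homo sapiens) for antiproliferative activity, read by CellTiter-Glo, with a stated time of 72 h; on this read-out higher numbers stand for weaker inhibition and lower numbers for stronger inhibition. Compound 3 `Cc1c(C)c(S(=O)(=O)N2CCC(N3CCC(C)CC3)CC2)c(C)c2c1OC(C)(C)C2` gives 1.2 nM in this assay. Compound 2 `Cc1ccc(-c2ccccc2S(=O)(=O)N2CCC(N3CCC(C)CC3)CC2)cc1` gives 366 nM in this assay, the highest of the three numbers, beyond the scatter from both compound 3 and compound 1, so that compound 2 is the weakest of the measured set.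

Compound 4 `CC1CCN(C2CCN(S(=O)(=O)c3ccccc3Br)CC2)CC1` has not yet been measured. It differs from compound 2 in one place: bromo in place of 4-methylphenyl on an aromatic carbon. Within the measured set, the ring substituents that accompany the lower numbers are small, as in compound 1 with 0.03 nM and compound 3 with 1.2 nM, whereas the large 4-methylphenyl of compound 2 accompanies 366 nM. On that basis the step from compound 2 to compound 4 is expected to go toward a lower number by a 12-fold lower number from compound 2 to compound 4 (1.09 log units; beyond the scatter), beyond the scatter. Compound 4 is therefore estimated at 30 nM, with a range from 3 nM to 300 nM.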

Compound 4, half-maximal inhibitory concentration: 3 nM
The estimate for compound 4 lay 10-fold (1.00 log units) above the measured number, within the range that was stated.
By their numbers in this assay, from the lowest: compound 1; then compound 3; then compound 4; then compound 2.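

For the compounds shown here, this is the first pair that differs in one place, so the change at this aromatic carbon can now be read on its own: in this assay, bromo in place of 4-methylphenyl gives a 120-fold lower number from compound 2 to compound 4 (2.09 log units; beyond the scatter), a large step beyond the scatter. The number at this position therefore depends strongly on the group it carries, and the counts of hydrogen-bond donors, hydrogen-bond acceptors and net charge do not separate the two groups, since they are the same for both. Nothing measured here accounts for the size of this step.

A single step cannot separate the loss of the aromatic ring from the arrival of bromine. From the compounds shown here alone, how chloro, methoxy, an amine or an unsubstituted phenyl would behave on this carbon remains open.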